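Swapping the amine side chain of compound 1

The compounds below may be only part of what the source reports. "The series", "measured", "known", "first", "only" and "open" are said of these compounds alone.

Of the compounds shown here, three have numbers so far in a functional assay on MCF7 cells (Homo sapiens) for inhibition; a lower number here means a stronger inhibitor, a higher number a weaker inhibitor. Compound 1 (`O=C(NO)c1ccc(-c2ccc(CNCc3ccccc3Cl)cn2)s1`) gives 110 nM, the lowest number of the three. Compound 2 (`O=C(NO)c1ccc(-c2cccc(CNCc3ccccc3)n2)s1`) gives 1900 nM, and compound 3 (`Cn1nc(C(F)(F)F)cc1-c1ccc(C(=O)NO)s1`) gives 11400 nM. Both of these numbers lie beyond the scatter from that of compound 1, which makes compound 1 the strongest inhibitor measured here.

Compound 4 (`O=C(NO)c1ccc(-c2ccc(CNCCOc3ccccc3)cn2)s1`) keeps the core of compound 1 but has phenoxymethyl in place of 2-chlorophenyl on a saturated chain carbon bound to an amine nitrogen. Within the data shown here, no pair of measured compounds isolates this change, so its size cannot be read directly from the data. The expectation starts from compound 1 at 110 nM, as the entering group still holds one six-membered aromatic ring of carbon only. The estimated step is a 1.6-fold higher number from compound 1 to compound 4 (0.21 log units; within the scatter), a slightly higher number and not beyond the scatter. For compound 4 the estimated value is 180 nM, with an expected range of 60 nM to 600 nM.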

Compound 4, half-maximal inhibitory concentration: 110 nM
Compound 4: middle estimate off by 1.6-fold (0.21 log units), on the high side; low and high end bracket the measured number.
By their numbers in this assay, from the lowest: compounds 1 and 4 (each within the scatter of the next); then compound 2; then compound 3.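

In this assay, phenoxymethyl in place of 2-chlorophenyl on a saturated chain carbon bound to an amine nitrogen gives no change at the digits printed from compound 1 to compound 4 (within the scatter). Among these compounds, this is the first single-place comparison, and it shows that this position accepts the loss of chlorine and the gain of an oxygen that adds a hydrogen-bond acceptor, with the six-membered aromatic ring of carbon kept, without a step beyond the scatter. Nothing available explains why the number holds.

As far as these compounds go, this one pair does not separate the removal of chlorine from the insertion of the oxygen-containing link, so the contribution of each remains unknown. Also open, from the compounds shown here alone, is whether the number holds when the aromatic ring gives way to a cyclohexyl ring or when a carboxylic acid stands at the end of the chain.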